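Measured Neighbours Frame an Open-Chain Analogue of Compound 2

The compounds below may be only part of what the source reports. "The series", "measured", "known", "first", "only" and "open" are said of these compounds alone.

- compound 1 `O=C1c2c[n+]([O-])c3ccccc3c2C(=O)c2c1c1ccccc1n2Cc1cn([C@H]2O[C@H](CO)[C@@H](O)[C@H]2O)nn1`: 1700 nM
- compound 2 `O=C1c2c[n+]([O-])c3ccccc3c2C(=O)c2c1c1ccccc1n2Cc1cn([C@@H]2C[C@H](O)[C@@H](CO)O2)nn1`: 130 nM

Among the measured compounds shown here, in a functional assay on MDA-MB-231 cells (Homo sapiens) for cytotoxicity, read by MTT assay, with a stated time of 72 h (on this read-out higher numbers stand for weaker inhibition and lower numbers for stronger inhibition), compound 2 gives 130 nM, the lower of the two numbers measured so far and the stronger inhibition. Compound 1 gives 1700 nM. The next analogue is compound 3 `O=C1c2c[n+]([O-])c3ccccc3c2C(=O)c2c1c1ccccc1n2Cc1cn(CC(O)CO)nn1`, still unmeasured. Its change from compound 2 is 2,3-dihydroxypropyl in place of 4-hydroxy-5-(hydroxymethyl)oxolan-2-yl on an aromatic nitrogen, so the five-membered non-aromatic ring gives way to a chain with no ring.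

For the measured compounds named here, only one measured step bears on this change, and only indirectly: a 13-fold lower number from compound 1 to compound 2 (1.12 log units; beyond the scatter). That large step, beyond the scatter, came with hydrogen in place of hydroxy on a saturated ring carbon, and it shows that compound 2 is sensitive to a change in this substituent. Going by the values given here, no measured compound yet carries an open chain, so the data give the direction only tentatively. A moderate rise in the number is expected, probably smaller than the measured step. The expected change is a 3.1-fold higher number from compound 2 to compound 3 (0.49 log units; beyond the scatter). For compound 3 the estimated value is 400 nM, with an expected range of 110 nM to 1500 nM.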

Compound 3, half-maximal inhibitory concentration: 1290 nM
The estimate for compound 3 lay 3.2-fold (0.51 log units) below the measured number; the range from low to high includes it.
By their numbers in this assay, from the lowest: compound 2; then compounds 3 and 1 (each within the scatter of the next).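

In this assay, putting 2,3-dihydroxypropyl in place of 4-hydroxy-5-(hydroxymethyl)oxolan-2-yl on the aromatic nitrogen gives a 9.9-fold higher number from compound 2 to compound 3 (1.00 log units; beyond the scatter), so this position responds to the loss of the ring as well as to the hydroxy change seen earlier, although both groups carry 2 hydrogen-bond donors. Set against 3,4-dihydroxy-5-(hydroxymethyl)oxolan-2-yl, the same chain gives a 1.3-fold lower number from compound 1 to compound 3 (0.12 log units; within the scatter), so a five-membered non-aromatic ring alone does not bring the low number: compound 1 has such a ring, yet it lies within the scatter of the open-chain compound 3, and among these three only compound 2 stands apart. No measurement shown here explains this result.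

The compounds shown leave open which part of the 4-hydroxy-5-(hydroxymethyl)oxolan-2-yl group accounts for the low number of compound 2, including the role of its 3 defined stereocentres. They also leave open how this position would respond to a longer chain, or to an amine or a carboxylic acid in place of the hydroxy groups on the chain.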